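Ring substituent swap on a pyrrolidine ketone series

The source may report more compounds than this note shows. Statements on the series, on what has been measured and on what is new or still open speak of the compounds shown alone.

Compound 1 `CCCCCCCCc1ccc(C(=O)C[C@@H]2CCCN2)cc1`: 57%
Compound 2 `CCCCCCCCc1ccc(C(=O)C[C@@H]2C[C@@H](O)CN2)cc1`: 46%
Compound 3 `CCCCCCCCc1ccc(C(=O)CC[C@H]2C[C@H](CO)CN2)cc1`: 46%

Of the compounds shown here, three sharing one core have been tested in a functional assay on FL5.12 cells (Mus musculus), read by flow cytometry, with a stated time of 3 h, tested at 10 uM; a lower number here means a weaker effect, a higher number a stronger effect of the compound at the concentration tested. Compound 3 sits level with compound 2 at the digits printed, the two together forming the lowest pair of the three numbers; the wider gap is a number 11 percentage points lower from compound 1 to compound 3 (beyond the scatter), while between compound 2 and compound 3 there is no change at the digits printed from compound 2 to compound 3 (within the scatter).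

Compound 4 `CCCCCCCCc1ccc(C(=O)CC[C@@H]2C[C@@H](O)CN2)cc1` has not yet been measured in this assay. Relative to compound 3 its change is a group of 6 heavy atoms (4 carbon, 1 nitrogen, 1 oxygen; one five-membered non-aromatic ring with 1 hetero atom) in place of a group of 7 heavy atoms (5 carbon, 1 nitrogen, 1 oxygen; one five-membered non-aromatic ring with 1 hetero atom), on a saturated chain carbon, two bonds along the chain from a carbonyl carbon. Going by the values given here, the entering 4-hydroxypyrrolidin-2-yl is the same ring that compound 2 carries, so the step that bears most directly on this change is the one from compound 2 to compound 3, which gave no change at the digits printed from compound 2 to compound 3 (within the scatter). Among the compounds with values here, the only step that moved beyond the scatter is the one from compound 1, which gave a number 11 percentage points lower from compound 1 to compound 2 (beyond the scatter), and compound 4 still carries a hydroxy on the ring.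

Compound 4 is therefore expected to give 46% in this assay, with a range of 36% to 56%, a step of no change at the digits printed from compound 3 to compound 4 (within the scatter) that is estimated to stay within the scatter.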

Compound 4, a percentage reported as activity, at one concentration (the size of the read-out at that concentration, not a potency): 52%
Beside the measured number, compound 4's estimate is 6 percentage points below it; measured number inside the range.
By their numbers in this assay, from the lowest: compounds 2, 3, 4 and 1 (each within the scatter of the next, the first and the last beyond it).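

In this assay, going by these compounds alone, putting 4-hydroxypyrrolidin-2-yl on a saturated chain carbon, two bonds along the chain from a carbonyl carbon, gives a number 6 percentage points higher from compound 3 to compound 4 (within the scatter) and is the first change read at this place, with the group that leaves and the one that enters matching in their counts of hydrogen-bond donors and acceptors. The other two comparisons, a number 6 percentage points higher from compound 2 to compound 4 (within the scatter) and a number 5 percentage points lower from compound 1 to compound 4 (within the scatter), both stay within the scatter, so compound 4 cannot be told apart from either compound 2 or compound 1, even though a number 11 percentage points lower from compound 1 to compound 2 (beyond the scatter) separates those two from each other. No measured information is available to explain these results.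

From the compounds shown here alone, whether an amine or a carboxylic acid in place of the hydroxy on the ring would move the number beyond the scatter remains open, as does the effect of a longer chain carrying the ring. With every number taken at one concentration, the compounds shown also leave open how they would compare in potency.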